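Swapping the aryl group on a sulfonamide, one step at a time

The source may report more compounds than this note shows. Statements on the series, on what has been measured and on what is new or still open speak of the compounds shown alone.

In an assay on brain for displacement of a labelled ligand from 5-hydroxytryptamine receptor 4 (Cavia porcellus), with a stated time of 30 min, in the presence of a further agent that is not named here (on this read-out higher numbers stand for weaker inhibition and lower numbers for stronger inhibition), compound 2 `COc1ccc(S(=O)(=O)NCCN2CCC(CCC(=O)c3cc(Cl)c(N)cc3OC)CC2)cc1Cl` gives 22.5 nM, while compound 1 `COc1cc(N)c(Cl)cc1C(=O)CCC1CCN(CCNS(=O)(=O)c2cc(Br)ccc2Br)CC1` gives 16.3 nM; these two values lie within the scatter of each other. Compound 3 `COc1cc(N)c(Cl)cc1C(=O)CCC1CCN(CCNS(=O)(=O)c2ccc3c(c2)NC(=O)CO3)CC1` differs from compound 2 by a group of 11 heavy atoms (8 carbon, 1 nitrogen, 2 oxygen; one six-membered non-aromatic ring with 2 hetero atoms, one six-membered aromatic ring of carbon only) in place of a group of 9 heavy atoms (7 carbon, 1 oxygen, 1 chlorine; one six-membered aromatic ring of carbon only), on a sulfonyl sulfur. Within the data shown here, the only measured step touching this position, a 1.4-fold higher number from compound 1 to compound 2 (0.14 log units; within the scatter), swapped one aryl group for another and stayed within the scatter, suggesting on two compounds alone that this group can be varied without a large shift. Therefore the expected step is a 1.1-fold higher number from compound 2 to compound 3 (0.05 log units; within the scatter). Compound 3 is estimated at 25 nM, with a range from 8 nM to 80 nM.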

Compound 3, inhibition constant: 6.2 nM
Estimate against measurement, compound 3: 4.0-fold (0.61 log units) above, outside the stated range (below it).
By their numbers in this assay, from the lowest: compound 3; then compounds 1 and 2 (each within the scatter of the next).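

In this assay, the group on the sulfonyl sulfur proves less interchangeable than the first pair suggested. Adding a six-membered non-aromatic ring with 2 hetero atoms to the aromatic ring gives a 3.6-fold lower number from compound 2 to compound 3 (0.56 log units; beyond the scatter) and a 2.6-fold lower number from compound 1 to compound 3 (0.42 log units; beyond the scatter), both modest but beyond the scatter. No measurement here accounts for this gain.

From the compounds shown here alone, whether that added ring itself is needed remains open, as does the role of its amide hydrogen. A phenyl group carrying an open-chain acetamide, or a naphthyl group, could help separate these possibilities.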